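The source may hold more compounds than are shown below. What is called first, only, known or untested is meant among the compounds shown, and "the series" means these compounds.

Measured compounds:
compound 1, `CC/C(=C(/c1ccc(/C=C/C(=O)O)cc1)c1cc2ccccc2[nH]1)c1ccccc1`, with 108 nM;
compound 2, `CC/C(=C(/c1ccc(/C=C/C(=O)O)cc1)c1cc2ccccc2[nH]1)c1ccccc1OC(F)(F)F`, with 206 nM;
compound 3, `CC/C(=C(/c1ccc(/C=C/C(=O)O)cc1)c1cc2ccccc2[nH]1)c1ccc(C#N)cc1`, with 278 nM.

All three numbers come from a functional assay on MCF7 cells (Homo sapiens) for inhibition; on this read-out lower numbers stand for stronger inhibition and higher numbers for weaker inhibition. Compound 2 stands second highest of the three; its nearest neighbour is compound 3, reached by a 1.3-fold higher number from compound 2 to compound 3 (0.13 log units; within the scatter), and the furthest is compound 1, from which it is separated by a 1.9-fold higher number from compound 1 to compound 2 (0.28 log units; within the scatter). Compound 4, `CC/C(=C(/c1ccc(/C=C/C(=O)O)cc1)c1cc2ccccc2[nH]1)c1cccc(Cl)c1Cl`, has not been measured. It differs from compound 2 by 2,3-dichlorophenyl in place of 2-(trifluoromethoxy)phenyl on a double-bonded chain carbon bound to a double-bonded chain carbon and a saturated chain carbon. Going by the values given here, the step that bears most directly on this change is the one from compound 2 to compound 3, since it also exchanges the whole phenyl group at the same place and is within the scatter. The two substitutions on that ring from the unsubstituted parent, a 1.9-fold higher number from compound 1 to compound 2 (0.28 log units; within the scatter) and a 2.6-fold higher number from compound 1 to compound 3 (0.41 log units; beyond the scatter), were small as well. Compound 4 is therefore expected to show no step beyond the scatter in this assay, a 1.0-fold lower number from compound 2 to compound 4 (0.01 log units; within the scatter), and its estimate is 200 nM with a range from 80 nM to 500 nM.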

Compound 4, half-maximal inhibitory concentration: 898 nM
The estimate for compound 4 lay 4.5-fold (0.65 log units) below the measured number; the whole stated range lies below it.
By their numbers in this assay, from the lowest: compounds 1, 2 and 3 (each within the scatter of the next, the first and the last beyond it); then compound 4.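

The ring on the double-bonded chain carbon proved less tolerant than compounds 1, 2 and 3 had suggested, since 2,3-dichlorophenyl gives a step beyond the scatter against each of them in this assay: a 4.4-fold higher number from compound 2 to compound 4 (0.64 log units; beyond the scatter) and a 3.2-fold higher number from compound 3 to compound 4 (0.51 log units; beyond the scatter). The largest step in the set runs from the unsubstituted phenyl (an 8.3-fold higher number from compound 1 to compound 4 (0.92 log units; beyond the scatter)), which makes compound 4 the weakest of the four. Nothing shown explains why this exchange costs more than the other ring changes.

The compounds shown leave open whether both chlorine atoms are needed for this loss or a single chlorine on the phenyl ring would produce it. They also leave open how a methoxy group or an amine on that ring would compare.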